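This account rests on a few compounds, and the source may have more. Where it says the series, first, only, none or still open, it means among the compounds named here.

Measured compounds:
- compound 1 `Fc1ccc(-c2nn3c(NC4CCCC4)cccc3c2-c2cc(NC3CCCC3)ncn2)cc1`: > 40000 nM
- compound 2 `Fc1ccc(-c2nn3c(NC4CCCC4)cccc3c2-c2ccsc2)cc1`: "not determined" (no result reported)
- compound 3 `Fc1ccc(-c2nn3c(NC4CCCC4)cccc3c2-c2ccoc2)cc1`: "not determined" (no result reported)

Three compounds share one core and differ only in the group on it. In an ADME assay on Vero cells (Chlorocebus sabaeus) for cytotoxicity (on this read-out lower numbers stand for higher toxicity in this test and higher numbers for lower toxicity in this test), compound 1 gives > 40000 nM, which is a limit of the assay and not a number. Compound 2 gives "not determined" (no result reported) in this assay. Compound 3 stands without a result: in this assay compound 3 gives "not determined" (no result reported), so no number places it, and the only numeric mark among the three is the limit of > 40000 nM in this assay, at which 1 of the 3 values shown sits.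

Compound 4 `NNc1cc(-c2c(-c3ccc(F)cc3)nn3c(NC4CCCC4)cccc23)ccn1` is the next compound, not yet measured. It differs from compound 3 by 2-(aminoamino)pyridin-4-yl in place of furan-3-yl on an aromatic carbon. Among the compounds with values here, with no measured step available, no direction for the step into compound 4 can be read from the numbers, and compound 1 suggests that the shared core tends to sit at the limit. Compound 4 is therefore estimated at 40000 nM in this assay, within 15000 nM to 100000 nM.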

Compound 4, half-maximal cytotoxic concentration: 40000 nM
Beside the measured number, compound 4's estimate shows no gap at the digits printed, within the range that was stated.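

Within the data shown here, no step into compound 4 can be read, as compound 2 and compound 3 give no number in this assay. Compound 1 offers only a limit. The compounds shown leave open how the group on this aromatic carbon shifts cytotoxicity.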